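Aryl-substituted pyrrolidine series: fucosidase inhibition so far absent

The compounds below may be only part of what the source reports. "The series", "measured", "known", "first", "only" and "open" are said of these compounds alone.

Values in an assay on isolated protein for inhibition of tissue alpha-L-fucosidase (Bos taurus), tested at 1000 uM; a lower number here means less inhibition, a higher number more inhibition at the concentration tested (going by the name of the read-out):
compound 1 `OC[C@@]1(c2ccc(F)cc2)NC[C@@H](O)[C@@H]1O`: 0%
compound 2 `COc1ccc([C@]2(CO)NC[C@@H](O)[C@@H]2O)cc1`: 2.7%
compound 3 `OC[C@@]1(c2ccc(O)cc2)NC[C@@H](O)[C@@H]1O`: 0%

Compound 2 carries the top number of the three, yet all three numbers sit together at the floor of the read-out. Among the compounds with values here, the step of a number 2.7 percentage points higher from compound 1 to compound 2 (within the scatter), the step of a number 2.7 percentage points lower from compound 2 to compound 3 (within the scatter) and the step of no change at the digits printed from compound 1 to compound 3 (within the scatter) are each within the scatter, so no member of this trio can be told apart from the others in this assay.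

Compound 4 `COc1ccc([C@]2(CO)NC[C@@H](O)[C@@H]2O)cc1OC` is the next member. It differs from compound 2 in one place: methoxy in place of hydrogen on an aromatic carbon. Within the data shown here, the steps that bear on this change are those that also alter the substituent on the aromatic ring, namely a number 2.7 percentage points higher from compound 1 to compound 2 (within the scatter) and a number 2.7 percentage points lower from compound 2 to compound 3 (within the scatter); both are flat. Nothing in the three measured compounds therefore points to a step beyond the scatter in this assay from adding a second methoxy group, and none is expected.

Compound 4 is expected to give 3% in this assay, with a range from 0% to 14%. The expected step is a number 0.3 percentage points higher from compound 2 to compound 4 (within the scatter), within the scatter.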

Compound 4, a percentage reported as inhibition, at one concentration (the size of the read-out at that concentration, not a potency): 0%
Compound 4: middle estimate off by 3 percentage points, on the high side; the range from low to high includes it.
By their numbers in this assay, from the lowest: compounds 1, 3, 4 and 2 (each within the scatter of the next).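

Methoxy in place of hydrogen on an aromatic carbon, ortho to a methoxy group, gives a number 2.7 percentage points lower from compound 2 to compound 4 (within the scatter) in this assay. The earlier steps shown here only exchanged one ring substituent for another, whereas this step occupies a second aromatic position, and the result still cannot be told apart from compound 2. A second methoxy group at this position therefore adds no detectable inhibition at the concentration tested, and no further data bear on this result.

With every value at the floor of the read-out, these compounds cannot show whether this position matters for inhibition at all. Open, from the compounds shown here alone, is whether an amine or a carboxylic acid here, or a longer chain in place of the methoxy group, would give a reading beyond the scatter.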